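Replacing hydroxy with amino in compound 3

The source may hold more compounds than are shown below. What is called first, only, known or untested is meant among the compounds shown, and "the series" means these compounds.

Compound 1 `S=C(N/N=C/c1ccc2ccccc2c1)N1CCOCC1` gives 32600 nM
Compound 2 `C/C(=N\NC(=S)N1CCOCC1)c1ccccc1` gives 32600 nM
Compound 3 `C/C(=N\NC(=S)N1CCOCC1)c1ccccc1O` gives 11200 nM

In a functional assay on MGC-803 cells (Homo sapiens) for antiproliferative activity, read by MTT assay, with a stated time of 72 h (on this read-out lower numbers stand for stronger inhibition and higher numbers for weaker inhibition), compound 3 has the lowest number of the three, and compound 1 and compound 2 show the same higher value. Compound 4 `C/C(=N\NC(=S)N1CCOCC1)c1ccccc1N` differs from compound 3 by a single change (amino in place of hydroxy on an aromatic carbon): amino in place of hydroxy on an aromatic carbon. Going by the values given here, only one measured step bears on this, the modest one for hydroxy in place of hydrogen (a 2.9-fold lower number from compound 2 to compound 3 (0.46 log units; beyond the scatter)). Among the compounds with values here, no amino compound has been measured yet, so a step no larger is expected, leaning towards a higher number and probably within the scatter (a 1.3-fold higher number from compound 3 to compound 4 (0.13 log units; within the scatter)). Compound 4 is estimated at 15000 nM (expected range 6000 nM to 35000 nM).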

Compound 4, half-maximal inhibitory concentration: > 64000 nM
Compound 4: only a limit was reported (the forecaster's own chance of this, stated with the estimate: 5%); middle value at least 4.2-fold (0.63 log units) away from the limit.
By their numbers in this assay, from the lowest: compound 3; then compounds 1 and 2 (each within the scatter of the next). At a limit, above all of these: compound 4.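

In this assay compound 4 is reported only as a limit: the limit of > 64000 nM in this assay, at which 1 of the 4 values shown sits. Even so, amino in place of hydroxy on this aromatic carbon, ortho to a large group, gives an at least 5.7-fold higher number from compound 3 to compound 4 (0.75 log units; beyond the scatter), so the two groups are not interchangeable at this position. Amino in place of hydrogen gives an at least 1.9-fold higher number from compound 2 to compound 4 (0.29 log units; that floor lies within the scatter), so it remains unsettled whether amino does any worse than hydrogen here. The compounds shown leave open how a methoxy group or a fluorine at this position would compare with hydroxy.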